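The compounds below may be only part of what the source reports. "The series", "measured", "known", "first", "only" and "open" are said of these compounds alone.

Three compounds have been measured in a functional assay on HCT-8 cells (Homo sapiens) for antiproliferative activity, read by MTT assay, with a stated time of 48 h; on this read-out lower numbers stand for stronger inhibition and higher numbers for weaker inhibition:

Compound 1, `CNCC(=O)Nc1cc(OC)ccc1C(=O)c1ccc2c(c1)C=CC(C)(C)O2`, gives 1010 nM.
Compound 2, `COc1ccc(C(=O)c2ccc3c(c2)C=CC(C)(C)O3)c(NC(=O)CN(C)C)c1`, gives 2420 nM.
Compound 3, `C=C(c1ccc(OC)cc1NC(=O)CN)c1ccc(OC)c2c1OC(C)(C)C=C2`, gives 190 nM.

Compound 1 and compound 2 share one core and differ in a single spot: methyl in place of hydrogen on an amine nitrogen. That change brought a 2.4-fold higher number from compound 1 to compound 2 (0.38 log units; beyond the scatter), so the extra methyl on the amine weakened the effect somewhat in this assay. Compound 3 is built on a different core and has the lowest number of the three; the difference between the two cores is not broken down here, so only the raw values can be set side by side.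

Compound 4, `C=C(c1ccc(OC)cc1NC(=O)CNC)c1ccc(OC)c2c1OC(C)(C)C=C2`, has not yet been measured. It relates to compound 3 the way compound 2 relates to compound 1: methyl in place of hydrogen on an amine nitrogen. The surroundings are not quite identical, though. In compound 1 the amine nitrogen that receives the methyl has two saturated chain carbons as its other neighbours, while in compound 3 it has only one saturated chain carbon, so this is the same kind of change rather than the same change.

Compound 4 is expected to show a 2.1-fold higher number from compound 3 to compound 4 (0.32 log units; beyond the scatter) in this assay, a step of about the size seen in a 2.4-fold higher number from compound 1 to compound 2 (0.38 log units; beyond the scatter), although that expectation rests on a single earlier pair. Compound 4 is therefore estimated at 400 nM in this assay, with a likely range from 150 nM to 1000 nM.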

Compound 4, half-maximal inhibitory concentration: 320 nM
Estimate against measurement, compound 4: 1.3-fold (0.10 log units) above, within the range that was stated.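

In this assay, placing the methyl on the amine nitrogen of the core of compound 3 gives a 1.7-fold higher number from compound 3 to compound 4 (0.23 log units; within the scatter), a step too small to be told apart from the ordinary variation between repeated measurements. The step seen on the core of compound 1 is beyond that variation, yet the two steps cannot be distinguished from each other: the same change on two cores in this assay, a 2.4-fold higher number (0.38 log units; beyond the scatter) from compound 1 to compound 2 and a 1.7-fold higher number (0.23 log units; within the scatter) from compound 3 to compound 4, 1.4-fold (0.15 log units) apart, within the scatter of two such steps This shows that, across these two pairs, the change carried over from one core to the other without a detectable difference in size, but it does not show that the step is truly identical on both cores, and two pairs say nothing about any further core; the two nitrogens also start from different surroundings, so this is the same kind of change rather than the very same one.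

The compounds shown leave open what a group larger than methyl, such as an ethyl group or a longer chain, would do on this amine nitrogen. They also leave open whether a dimethylamino group on the core of compound 3 would follow the same small step.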